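This account rests on a few compounds, and the source may have more. Where it says the series, first, only, none or still open, it means among the compounds named here.

Working notes on the series in a functional assay on OVCAR-3 cells (Homo sapiens) for cytotoxicity, read by sulforhodamine B assay; on this read-out higher numbers stand for weaker inhibition of growth and lower numbers for stronger inhibition of growth:

Compound 1 `CC1=CC[C@@H]([C@@](C)(O)CCCC(C)(C)NC(=S)N/N=C\c2ccc(C)cc2)CC1`: 11800 nM
Compound 2 `CC1=CC[C@@H]([C@@](C)(O)CCCC(C)(C)NC(=S)N/N=C\c2ccc(N(C)C)cc2)CC1`: > 100000 nM (a limit)
Compound 3 `CC1=CC[C@@H]([C@@](C)(O)CCCC(C)(C)NC(=S)N/N=C\c2ccccc2[N+](=O)[O-])CC1`: 16200 nM

Compound 3 sits level with compound 1 (a 1.4-fold higher number from compound 1 to compound 3 (0.14 log units; within the scatter)) and well clear of the limit reached by compound 2 (an at least 6.1-fold lower number from compound 2 to compound 3 (0.79 log units; beyond the scatter)). Next comes compound 4 `CC1=CC[C@@H]([C@@](C)(O)CCCC(C)(C)NC(=S)N/N=C\c2cccc([N+](=O)[O-])c2)CC1`, which differs from compound 3 as follows: 3-nitrophenyl in place of 2-nitrophenyl on a carbon with a double bond to nitrogen. Replacing the aryl group of compound 1 with 2-nitrophenyl stayed within the scatter (a 1.4-fold higher number from compound 1 to compound 3 (0.14 log units; within the scatter)). Only the dimethylamino change was large (an at least 8.4-fold higher number from compound 1 to compound 2 (0.92 log units; beyond the scatter)). Among the measured compounds shown here, no nitro isomer pair has been measured yet, so the expectation rests on compound 3 and compound 1. No step beyond the scatter is expected in this assay (a 1.1-fold lower number from compound 3 to compound 4 (0.03 log units; within the scatter)). For compound 4 the estimated value is 15000 nM (expected range 7000 nM to 40000 nM).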

Compound 4, concentration for total growth inhibition: 40800 nM
Beside the measured number, compound 4's estimate is 2.7-fold (0.43 log units) below it; measured number outside the range, above it.
By their numbers in this assay, from the lowest: compounds 1 and 3 (each within the scatter of the next); then compound 4. At a limit, above all of these: compound 2.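

In this assay, among the compounds shown here, 3-nitrophenyl in place of 2-nitrophenyl gives a 2.5-fold higher number from compound 3 to compound 4 (0.40 log units; beyond the scatter) and so shows that the place of the nitro group on the aryl ring matters, which no earlier pair could show. Unlike 2-nitrophenyl, 3-nitrophenyl also stands apart from 4-methylphenyl on this carbon with a double bond to nitrogen, as a 3.5-fold higher number from compound 1 to compound 4 (0.54 log units; beyond the scatter) shows. The 4-(dimethylamino)phenyl value is a limit, so an at least 2.4-fold lower number from compound 2 to compound 4 (0.38 log units; beyond the scatter) is only a bound.

Open, on these data alone, is where 4-nitrophenyl would fall against the two nitro isomers, and whether 3-aminophenyl would follow 3-nitrophenyl.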